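Trifluoromethoxy in place of dimethylamino: cytotoxicity notes

This account rests on a few compounds, and the source may have more. Where it says the series, first, only, none or still open, it means among the compounds named here.

In an ADME assay on HepG2 cells (Homo sapiens) for cytotoxicity, with a stated time of 72 h (a higher number here means that more compound is needed for the effect, a lower number that less compound is needed), compound 1 `CCc1ccc(NC(=O)Nc2cc(C)nc3ccccc23)cc1` gives 17000 nM. Compound 2 `Cc1cc(NC(=O)Nc2ccc(N(C)C)cc2)c2ccccc2n1` gives > 25000 nM in this assay, and this is a limit, not a number. Compound 3 `Cc1cc(NC(=O)Nc2cc(F)cc(F)c2)c2ccccc2n1` gives > 25000 nM, which is also a limit. Compound 2 therefore has no numerical position in the series and stands at the limit of > 25000 nM in this assay, at which 2 of the 3 values shown sit.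

Compound 4 `Cc1cc(NC(=O)Nc2ccc(OC(F)(F)F)cc2)c2ccccc2n1` carries trifluoromethoxy in place of dimethylamino on an aromatic carbon, para to a large group: trifluoromethoxy in place of dimethylamino on an aromatic carbon.

For the measured compounds named here, one measured step bears on this change: an at least 1.4-fold higher number from compound 1 to compound 2 (0.16 log units; that floor lies within the scatter). It also exchanges a group on an aromatic carbon, and its size gives no sign of a large effect from such an exchange. No step beyond the scatter is therefore expected in this assay. Any small shift is expected towards a lower number, with compound 1 at 17000 nM as the only numerical anchor. The expected step is an at least 1.2-fold lower number from compound 2 to compound 4 (0.09 log units; that floor lies within the scatter). A result reported only as a limit remains a real possibility. For compound 4 the estimated value is 20000 nM, with an expected range of 9000 nM to 40000 nM.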

Compound 4, half-maximal effective concentration: 15000 nM
Compound 4: middle estimate off by 1.3-fold (0.12 log units), on the high side; measured number inside the range.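

Working notes on the position para to a large group: in this assay, trifluoromethoxy in place of dimethylamino gives an at least 1.6-fold lower number from compound 2 to compound 4 (0.22 log units; that floor lies within the scatter) and so shows no step beyond the scatter, although only a floor on its size can be read. Trifluoromethoxy in place of ethyl gives a 1.1-fold lower number from compound 1 to compound 4 (0.05 log units; within the scatter) and so leaves compound 1 and compound 4 indistinguishable here, which gives this position a second numerical value and shows that the exchange of ethyl for a larger group with fluorine atoms leaves the number in place. The step to compound 4 has only a floor because compound 2 carries a limit, not a number: the limit of > 25000 nM in this assay, at which 2 of the 4 values shown sit.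

Going by these compounds, whether dimethylamino truly separates compound 2 from compound 4 beyond the scatter remains open, since the size of that step has no upper bound. Also open, on these data alone, is whether a carboxylic acid, a primary amine or a longer chain on this aromatic carbon would move the number beyond the scatter, or whether the values here stay flat across such exchanges.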